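The source may hold more compounds than are shown below. What is called first, only, known or untested is meant among the compounds shown, and "the series" means these compounds.

The measured compounds:
Compound 1 `O=C(NC1CCN(C2CC2)C1)c1cc(-c2ccc(NS(=O)(=O)c3cccc(Cl)c3Cl)cc2)nc2[nH]ncc12` gives 610 nM in an assay for inhibition of serine/threonine-protein kinase Sgk1 (Homo sapiens), with stated times of 30 min and 60 min, in the presence of a further agent that is not named here; a lower number here means a stronger inhibitor, a higher number a weaker inhibitor.
Compound 2 `O=C(NC1CCN(CC2CC2)C1)c1cc(-c2ccc(NS(=O)(=O)c3cccc(Cl)c3Cl)cc2)nc2[nH]ncc12` gives 35 nM in this assay.
Compound 3 `CN(C)CCCNC(=O)c1cc(-c2ccc(NS(=O)(=O)c3cccc(Cl)c3Cl)cc2)nc2[nH]ncc12` gives 633 nM in this assay.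

Compound 2 has the lowest number of the three, and both of its steps lie beyond the scatter: a 17-fold lower number from compound 1 to compound 2 (1.24 log units; beyond the scatter) and an 18-fold higher number from compound 2 to compound 3 (1.26 log units; beyond the scatter). Compound 4 `CCN1CCC(CNC(=O)c2cc(-c3ccc(NS(=O)(=O)c4cccc(Cl)c4Cl)cc3)nc3[nH]ncc23)C1` differs from compound 2 in one place: (1-ethylpyrrolidin-3-yl)methyl in place of 1-(cyclopropylmethyl)pyrrolidin-3-yl on an amide-type nitrogen. Within the data shown here, two measured steps bear on this change. The first shows how sensitive the number is to the group on the ring nitrogen: a 17-fold lower number from compound 1 to compound 2 (1.24 log units; beyond the scatter). The second shows the cost of giving up the 1-(cyclopropylmethyl)pyrrolidin-3-yl group altogether for an open chain: an 18-fold higher number from compound 2 to compound 3 (1.26 log units; beyond the scatter). Compound 4 keeps a pyrrolidine ring but carries ethyl instead of cyclopropylmethyl on its nitrogen and attaches through a methyl, so a higher number is expected, probably smaller than either measured step. The expected step is a 5.7-fold higher number from compound 2 to compound 4 (0.76 log units; beyond the scatter); compound 4 is estimated at 200 nM, between 60 nM and 700 nM.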

Compound 4, half-maximal inhibitory concentration: 109 nM
Compound 4: the middle estimate sits 1.8-fold (0.26 log units) above what was measured, within the range that was stated.
By their numbers in this assay, from the lowest: compound 2; then compound 4; then compounds 1 and 3 (each within the scatter of the next).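

On this amide-type nitrogen, replacing 1-(cyclopropylmethyl)pyrrolidin-3-yl with (1-ethylpyrrolidin-3-yl)methyl gives a 3.1-fold higher number from compound 2 to compound 4 (0.49 log units; beyond the scatter), a modest loss that is much smaller than the large steps seen earlier. The new group also keeps a clear advantage over both weaker groups, with a 5.8-fold lower number from compound 3 to compound 4 (0.76 log units; beyond the scatter) against the open chain and a 5.6-fold lower number from compound 1 to compound 4 (0.75 log units; beyond the scatter) against the 1-cyclopropylpyrrolidin-3-yl group, so a good number here does not depend on the 1-(cyclopropylmethyl)pyrrolidin-3-yl group alone. No measurement here gives a reason for these steps.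

The change from compound 2 to compound 4 alters the group on the ring nitrogen and adds a methyl link at once, and the compounds shown do not separate these two parts. A 1-ethylpyrrolidin-3-yl group or a (1-(cyclopropylmethyl)pyrrolidin-3-yl)methyl group on the same amide-type nitrogen would show how much each part contributes.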